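From 2-Methoxyphenyl to 2,6-Dimethylphenyl on the Shared Core

The source may report more compounds than this note shows. Statements on the series, on what has been measured and on what is new or still open speak of the compounds shown alone.

Of the compounds shown here, three of the shared core have been measured in a functional assay on HUVEC cells (Homo sapiens); on this read-out lower numbers stand for an effect already at smaller amounts and higher numbers for an effect only at larger amounts of compound. Compound 1 `COC1=C(C)C(=O)/C(=C(O)/C=C/c2ccc(OC)cc2)C(=O)C1(C)C` carries a 4-methoxyphenyl group; in this assay compound 1 gives < 4 ug/mL, which is a limit of the assay and not a number. Compound 2 `COC1=C(C)C(=O)/C(=C(O)/C=C/c2ccccc2OC)C(=O)C1(C)C` carries a 2-methoxyphenyl group, and in this assay compound 2 gives < 4 ug/mL, again only a limit. Compound 3 `COC1=C(C)C(=O)/C(=C(O)/C=C/c2ccc(O)cc2)C(=O)C1(C)C` carries a 4-hydroxyphenyl group, and in this assay compound 3 gives < 4 ug/mL, also a limit. Compound 2 thus stands at the same limit as the other two (the limit of < 4 ug/mL in this assay, at which 3 of the 3 values shown sit). The step that the two limits leave unreadable from compound 1 to compound 2 and the step that the two limits leave unreadable from compound 2 to compound 3 both exchange the group on the double-bonded chain carbon, and the step that the two limits leave unreadable from compound 1 to compound 3 alters that group's substituent; none of them can be read in size, as every value is a limit.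

Compound 4 `COC1=C(C)C(=O)/C(=C(O)/C=C/c2c(C)cccc2C)C(=O)C1(C)C` is not yet measured. It differs from compound 2 as follows: 2,6-dimethylphenyl in place of 2-methoxyphenyl on a double-bonded chain carbon bound to a double-bonded chain carbon. For the measured compounds named here, the steps that bear on this exchange are unreadable, so no direction can be drawn from them beyond the observation that every variant so far sits at the limit. Compound 4 is therefore expected to give about 2 ug/mL in this assay, between 0.5 ug/mL and 6 ug/mL, with a fair chance that only a limit is reported. The step that the limit leaves unreadable from compound 2 to compound 4 is accordingly estimated to stay within the scatter.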

Compound 4, concentration for half-maximal effect: < 4 ug/mL
Compound 4 was reported as a limit; the forecaster's own chance of this, stated with the estimate: 65%; the middle value is on the limit's open side.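

In this assay compound 4 gives < 4 ug/mL, which is a limit of the assay and not a number. None of the steps joining compound 4 to compound 1, compound 2 and compound 3 can be read in size, and all four compounds stand at the same limit: the limit of < 4 ug/mL in this assay, at which 4 of the 4 values shown sit.

The compounds shown leave open how the groups on the double-bonded chain carbon rank, or whether they differ at all.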